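The source may report more compounds than this note shows. Statements on the series, on what has been measured and on what is new or still open speak of the compounds shown alone.

Compound 3 `COc1cc2ncnc(Nc3cccc(Cl)c3F)c2cc1OCCCCC(=O)Nc1ccc(S(N)(=O)=O)cc1` gives the lowest number of the three measured compounds in a functional assay on A-431 cells (Homo sapiens) for antiproliferative activity, read by MTT assay, with a stated time of 72 h; a higher number here means a weaker inhibitor, a lower number a stronger inhibitor: compound 3 gives 5560 nM, whereas compound 2 `COc1cc2ncnc(Nc3ccc(F)cc3)c2cc1OCCCCC(=O)Nc1ccc(S(N)(=O)=O)cc1` gives 18600 nM and compound 1 `COc1cc2ncnc(Nc3cccc(Cl)c3)c2cc1OCCCCC(=O)Nc1ccc(S(N)(=O)=O)cc1` gives 30400 nM. The three differ only in the aryl group on the nitrogen on an aromatic ring of the shared core. Compound 4 `COc1ccccc1Nc1ncnc2cc(OC)c(OCCCCC(=O)Nc3ccc(S(N)(=O)=O)cc3)cc12` keeps everything else and changes that aryl group once more: 2-methoxyphenyl in place of 3-chloro-2-fluorophenyl on a nitrogen on an aromatic ring. Going by the values given here, three measured steps bear on this place. a 1.6-fold lower number from compound 1 to compound 2 (0.21 log units; within the scatter). a 5.5-fold lower number from compound 1 to compound 3 (0.74 log units; beyond the scatter). a 3.3-fold lower number from compound 2 to compound 3 (0.52 log units; beyond the scatter). Thus the aryl group on this nitrogen has moved the number in this assay by modest amounts, and compound 3 carries the pattern that gave the lowest number. Among the compounds with values here, compound 4 gives up the chlorine and the fluorine of that pattern for a methoxy group, and no measured compound carries a methoxyphenyl here, so the direction rests on the observation that the halogen pattern of compound 3 was the only one to lower the number beyond the scatter. Compound 4 is therefore expected to give a higher number, with the step of a 3.6-fold higher number from compound 3 to compound 4 (0.56 log units; beyond the scatter) estimated to be modest, about the size of the measured steps. Compound 4 is estimated at 20000 nM in this assay, within a range from 7000 nM to 60000 nM.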

Compound 4, half-maximal inhibitory concentration: 24200 nM
The estimate for compound 4 lay 1.2-fold (0.08 log units) below the measured number; measured number inside the range.
By their numbers in this assay, from the lowest: compound 3; then compounds 2, 4 and 1 (each within the scatter of the next).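

In this assay, going by these compounds alone, the 2-methoxyphenyl group, the first aryl group at this place to carry oxygen rather than halogen, does not retain the low number of the 3-chloro-2-fluorophenyl group, with a 4.4-fold higher number from compound 3 to compound 4 (0.64 log units; beyond the scatter). Against the two singly halogenated aryl groups it shows no separation, with a 1.3-fold higher number from compound 2 to compound 4 (0.11 log units; within the scatter) and a 1.3-fold lower number from compound 1 to compound 4 (0.10 log units; within the scatter), so compounds 1, 2 and 4 now form one level within the scatter of each other, and compound 3 alone stands apart as the strongest of the four in this assay. No measurement shown here accounts for that separation.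

The compounds leave open whether the lower number of compound 3 requires the chloro and fluoro groups together on one ring, or whether the fluoro group alone, on an otherwise unsubstituted phenyl, would give it. Also open, on these data alone, is how a nitrile or an ethynyl group on that phenyl ring, an amine on the same ring, or a longer chain linking the shared core to the amide would move the number.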